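The source may report more compounds than this note shows. Statements on the series, on what has been measured and on what is new or still open speak of the compounds shown alone.

Working notes on the series

Three compounds of the series have been run in a functional assay on NCI-H460 cells (Homo sapiens) for cytotoxicity, read by MTT assay, with a stated time of 72 h; on this read-out lower numbers stand for stronger inhibition and higher numbers for weaker inhibition. Compound 1 `COc1ccc(/C=C2\CN(C)C/C(=C\c3ccc(OC)c(OC)c3)C2=O)cc1OC` gives 3100 nM. Compound 2 `CCN1C/C(=C\c2ccc(OC)c(OC)c2)C(=O)/C(=C/c2ccc(OC)c(OC)c2)C1` gives 3600 nM. Compound 3 `COc1cc(/C=C2\CN(C(=O)C(C)C)C/C(=C\c3cc(OC)c(OC)c(OC)c3)C2=O)cc(OC)c1OC` carries a different core from compound 2, and the difference between the two cores is not broken down here. In this assay compound 3 gives 2000 nM.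

One single-point change is available within the measured set. Between compound 2 and compound 1 the change is hydrogen in place of methyl on a saturated chain carbon bound to an amine nitrogen in a ring. The step it made is a 1.2-fold lower number from compound 2 to compound 1 (0.06 log units; within the scatter), so the two values sit together within the usual spread of repeats.

Compound 4 `CCC(=O)N1C/C(=C\c2cc(OC)c(OC)c(OC)c2)C(=O)/C(=C/c2cc(OC)c(OC)c(OC)c2)C1` has not yet been run in this assay. It differs from compound 3 by hydrogen in place of methyl on a saturated chain carbon bound to a carbonyl carbon and a saturated chain carbon. Among the compounds with values here, this is the same kind of change as the one from compound 2 to compound 1, a methyl leaving and a hydrogen entering, but not the same change: in the measured pair the place is on a saturated chain carbon bound to an amine nitrogen in a ring, whereas here it is on a saturated chain carbon bound to a carbonyl carbon and a saturated chain carbon.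

Within the data shown here, on the one comparable step, compound 4 is expected to stay close to compound 3 in this assay, with an estimated step of no change at the digits printed from compound 3 to compound 4 (within the scatter) beside the measured 1.2-fold lower number from compound 2 to compound 1 (0.06 log units; within the scatter). That expectation rests only on the step from compound 2 to compound 1 and on the value that compound 3 gives, 2000 nM. The estimate for compound 4 in this assay is 2000 nM, expected to fall between 1000 nM and 4000 nM.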

Compound 4, half-maximal inhibitory concentration: 2700 nM
For compound 4 the middle estimate is 1.4-fold (0.13 log units) below the measured one, and the stated range covers the measured number.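

In this assay the loss of a methyl in favour of hydrogen on the acyl chain, isopropylcarbonyl to propanoyl, gives a 1.4-fold higher number from compound 3 to compound 4 (0.13 log units; within the scatter) and so leaves the two compounds together within the usual spread of repeats. Set beside the earlier step on the other core, the change reads alike on both: the same change on two cores in this assay, a 1.2-fold lower number (0.06 log units; within the scatter) from compound 2 to compound 1 and a 1.4-fold higher number (0.13 log units; within the scatter) from compound 3 to compound 4, 1.6-fold (0.20 log units) apart, within the scatter of two such steps. This shows that in these two pairs the change leaves the number where repeats would put it, but it does not show a transfer of any real effect from one core to another: neither step has a direction that can be trusted, the two places differ, one on a chain bound to an amine nitrogen in a ring and the other on a chain bound to a carbonyl carbon, and two pairs say nothing about further cores.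

The compounds shown leave open whether any change at this end of the molecule can move the number beyond the scatter, since all the groups there are short: methyl, ethyl, isopropylcarbonyl and propanoyl. A longer chain, or a chain ending in an amine or a carboxylic acid, would test that, and only a step of that kind could show whether a change carries from one core to the other.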